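Sulfonyl aryl swap on the hydrazide series

This account rests on a few compounds, and the source may have more. Where it says the series, first, only, none or still open, it means among the compounds named here.

Two compounds of this hydrazide series have numbers in a functional assay on SF-268 cells (Homo sapiens) for inhibition, tested at 10 uM; a lower number here means less inhibition, a higher number more inhibition at the concentration tested (going by the name of the read-out). Compound 1 `O=C(NNS(=O)(=O)c1ccc(Cl)cc1Cl)c1cccnc1Nc1ccc(Cl)cc1` has the lower of the two numbers: in this assay compound 1 gives 34%. Compound 2 `COc1ccc(Nc2ncccc2C(=O)NNS(=O)(=O)c2ccc(C)cc2)cc1` stands far above it; in this assay compound 2 gives 106%, a gap beyond the scatter. Among the measured compounds shown here, compound 2 differs from compound 1 in more than one place, so no single-change step between measured compounds is known, and the pair only shows that the series can span the whole range of the read-out.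

Compound 3 `CC(=O)Nc1ccc(S(=O)(=O)NNC(=O)c2cccnc2Nc2ccc(Cl)cc2)cc1` is the next compound to be measured. It keeps the core of compound 1 and changes one group on the sulfonyl sulfur: 4-acetamidophenyl in place of 2,4-dichlorophenyl on a sulfonyl sulfur

For the measured compounds named here, with no single-change step to lean on, the expectation rests on where compound 1 stands and on the fact that compound 2 reaches a much higher number in this assay. A rise beyond the scatter is expected, a number 21 percentage points higher from compound 1 to compound 3 (beyond the scatter), though with wide uncertainty since the direction is inferred rather than measured. For compound 3 the estimate in this assay is 55%, with a range from 20% to 95%.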

Compound 3, a percentage reported as inhibition, at one concentration (the size of the read-out at that concentration, not a potency): 60%
For compound 3 the middle estimate is 5 percentage points below the measured one, and the stated range covers the measured number.
By their numbers in this assay, from the lowest: compound 1; then compound 3; then compound 2.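

The group on a sulfonyl sulfur now has its first single-change step: in this assay, 4-acetamidophenyl in place of 2,4-dichlorophenyl gives a number 26 percentage points higher from compound 1 to compound 3 (beyond the scatter). With the rest of the core of compound 1 held fixed, this shows that the read-out responds to this group alone, which compound 1 and compound 2 could not show because they differ in more than one place. The swap removes both chlorines and adds an acetamide at the same time, and no measurement at hand accounts for the change in the number or assigns it to either feature.

Still open, on these data alone, is whether the step follows from the loss of the chlorines or from the gain of the acetamide; a plain phenyl, a phenyl with a single chlorine, or an amine or a carboxylic acid in place of the acetamide would help to separate the two. Also open, as far as these compounds go, is whether the same swap gives a step of similar size when the rest of the core is changed.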